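A few compounds are considered here, and "the series" means these few. Any claim that something is new, unique, unknown or untested is made for them only; others in the source may bear on it.

Compound 1 `C=CC[C@H]1C[C@]2([C@@H](C)Cc3ccc(OC)c(OC)c3)OCOC2=CC1=O` is the reference point of this pair. Among the compounds with values here, in a functional assay on M14 cells (Homo sapiens) for antiproliferative activity, with a stated time of 72 h (a lower number here means a stronger inhibitor, a higher number a weaker inhibitor), compound 1 gives 110 nM, the lowest of the two numbers so far. Its epimer compound 2 `C=CC[C@H]1C[C@]2([C@H](C)Cc3ccc(OC)c(OC)c3)OCOC2=CC1=O` gives in this assay a value of 300 nM, a step of a 2.7-fold higher number from compound 1 to compound 2 (0.44 log units; beyond the scatter) that rests on the fact that compounds 1 and 2 differ only in the configuration as drawn alone. Compound 3 `C=CC[C@H]1C[C@]2([C@@H](C)Cc3ccc(OC)c(O)c3)OCOC2=CC1=O` keeps the stereochemistry of compound 1 and differs only by hydrogen in place of methyl on an oxygen on an aromatic ring. Within the data shown here, no measured step touches this change: the single step concerns configuration at a saturated chain carbon and says nothing about the groups on the aromatic ring. The size of the step in this assay is therefore left open, and the expectation is a change of the order of the scatter, with no settled direction. Compound 3 is estimated at 150 nM, between 60 nM and 400 nM, which means an expected step of a 1.4-fold higher number from compound 1 to compound 3 (0.13 log units; within the scatter).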

Compound 3, half-maximal inhibitory concentration: 8 nM
Compound 3: middle estimate off by 19-fold (1.27 log units), on the high side; the whole stated range lies above it.
By their numbers in this assay, from the lowest: compound 3; then compound 1; then compound 2.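

In this assay the change from methoxy to hydroxy, on an oxygen on an aromatic ring, gives a 14-fold lower number from compound 1 to compound 3 (1.14 log units; beyond the scatter) and brings compound 3 to 8 nM as the new low point of the series. This step is larger than the configuration step, a 2.7-fold higher number from compound 1 to compound 2 (0.44 log units; beyond the scatter), so of the two places varied so far the oxygen on the aromatic ring is the more sensitive. No available finding accounts for the size of the step at this oxygen.

As far as these compounds go, whether an ethoxy group or an amine in place of the hydroxy would hold a number near that of compound 3 remains open. Also open, from the compounds shown here alone, are whether the same change carries over to the configuration of compound 2 and what the remaining methoxy contributes.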